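The source may report more compounds than this note shows. Statements on the series, on what has been measured and on what is new or still open speak of the compounds shown alone.

Compound 1 (`CNC(=O)c1cc(C(=O)N[C@H]2CC[C@H](O)CC2)n([C@@H](C)c2cccc(Cl)c2)n1`) gives 235 nm/s
Compound 2 (`CNC(=O)c1cc(C(=O)N[C@H]2CC[C@H](O)CC2)c([C@@H](C)c2cccc(Cl)c2)o1`) gives 150 nm/s

Both numbers come from an ADME assay for permeability (a higher number here means that the compound crosses the layer faster, a lower number that the compound crosses the layer more slowly), and they lie within the usual scatter of each other, so compound 2 cannot be told apart from compound 1 on this evidence. Compound 3 (`CNC(=O)c1cc(C(=O)N[C@H]2CC[C@H](O)CC2)c([C@@H](C)c2ccc(Cl)cc2)o1`) has not been measured yet. It differs from compound 2 in one place (4-chlorophenyl in place of 3-chlorophenyl on a saturated chain carbon bound to an aromatic carbon and a saturated chain carbon), with 4-chlorophenyl in place of 3-chlorophenyl on a saturated chain carbon bound to an aromatic carbon and a saturated chain carbon. Among the compounds with values here, no measured pair shows a change of this kind, so the data give no direct guide to its size. The estimate therefore starts from compound 2 (150 nm/s), and no shift beyond the scatter is expected in this assay for this swap. The expected change is small (a 1.1-fold higher number from compound 2 to compound 3 (0.03 log units; within the scatter)). Compound 3 is estimated at 160 nm/s (expected range 85 nm/s to 300 nm/s).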

Compound 3, apparent permeability: 150 nm/s
Compound 3: middle estimate off by 1.1-fold (0.03 log units), on the high side; measured number inside the range.
By their numbers in this assay, from the lowest: compounds 2, 3 and 1 (each within the scatter of the next).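

In this assay, putting 4-chlorophenyl in place of 3-chlorophenyl on a saturated chain carbon bound to an aromatic carbon and a saturated chain carbon gives no change at the digits printed from compound 2 to compound 3 (within the scatter). Within the data shown here, this pair is the first direct test of this position, since the earlier compounds both carry 3-chlorophenyl: on the core shared by compound 2 and compound 3, the swap leaves no mark that can be told from the scatter. Nothing measured here explains why the two compounds read alike.

Still open, as far as these compounds go, is how this assay would respond to a larger change at this position, such as plain phenyl without the chlorine, or a methoxy or trifluoromethyl group on the ring. From the compounds shown here alone, it is also open whether the same swap would read alike on the core of compound 1.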